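The source may hold more compounds than are shown below. What is called first, only, known or untested is meant among the compounds shown, and "the series" means these compounds.

Measured so far:
Compound 1, `CC1CC/C(=N\Nc2ccccc2F)c2ncc(C(=O)O)c(=O)n21`: > 1000 umol/kg
Compound 2, `CC1CC/C(=N\Nc2ccccc2O)c2ncc(C(=O)O)c(=O)n21`: > 100 umol/kg

In a functional assay on the whole organism for inhibition, with Rattus norvegicus as the target (on this read-out higher numbers stand for an effect only at larger amounts of compound and lower numbers for an effect already at smaller amounts), compound 1 reaches only a limit, > 1000 umol/kg. In this assay compound 2 likewise gives only a limit, > 100 umol/kg. The step that the two limits leave unreadable from compound 1 to compound 2 therefore cannot be read, as the limit of > 100 umol/kg in this assay, at which 1 of the 2 values shown sits, and the limit of > 1000 umol/kg in this assay, at which 1 of the 2 values shown sits, show. Compound 3, `CC1CC/C(=N\Nc2ccccc2C(F)(F)F)c2ncc(C(=O)O)c(=O)n21`, differs from compound 2 by trifluoromethyl in place of hydroxy on an aromatic carbon. Going by the values given here, no measured step gives a readable size for such a change, so no shift beyond the scatter in this assay is expected in either direction. Compound 3 is estimated at 1000 umol/kg, between 300 umol/kg and 3000 umol/kg. This corresponds to an expected step that the limit leaves unreadable from compound 2 to compound 3.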

Compound 3, dose for 50% inhibition: > 1000 umol/kg
Compound 3: only a limit was reported; the forecaster's own chance of this, stated with the estimate: 85%; the middle value sits exactly at the limit.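

In this assay, going by these compounds alone, compound 3 reaches only the limit > 1000 umol/kg and so no step to it from compound 1 or compound 2 can be read. On these data alone, whether fluoro, hydroxy or trifluoromethyl on the aromatic carbon makes any difference in this assay remains open.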